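The source may hold more compounds than are shown below. What is called first, only, known or untested is meant among the compounds shown, and "the series" means these compounds.

Measured in a functional assay on CCRF-CEM cells (Homo sapiens) for cytotoxicity, read by sulforhodamine B assay, with a stated time of 48 h, tested at 0.1 uM; on this read-out higher numbers stand for a weaker effect at the one concentration tested and lower numbers for a stronger effect:

- compound 1 `COc1ccc(-c2cc(/C=C/C(=O)c3ccc(OC)c(OC)c3)[nH]n2)cc1`: 97%
- compound 2 `COc1cc(-c2cc(/C=C/C(=O)c3ccc(Cl)c(Cl)c3)[nH]n2)cc(OC)c1OC`: 98%
- compound 3 `COc1ccc(C(=O)/C=C/c2cc(-c3cc(OC)c(OC)c(OC)c3)n[nH]2)cc1`: 98%

Compound 3 stands level with compound 2 at the digits shown, and compound 1 lies within the scatter of both, so the three values cannot be ordered. Going by the values given here, the only single-place step on record, no change at the digits printed from compound 2 to compound 3 (within the scatter), swaps the aryl on the carbonyl carbon and leaves the read-out unchanged within the scatter.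

Compound 4 `COc1cc(-c2cc(/C=C/C(=O)c3ccc(F)c(F)c3)[nH]n2)cc(OC)c1OC` differs from compound 3 by 3,4-difluorophenyl in place of 4-methoxyphenyl on a carbonyl carbon. This is again a swap of the aryl on the carbonyl carbon, the same place as in no change at the digits printed from compound 2 to compound 3 (within the scatter), which showed no change. No step beyond the scatter is therefore expected: compound 4 is estimated at 97% (range 90% to 102%), an expected step of a number 1 percentage points lower from compound 3 to compound 4 (within the scatter).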

Compound 4, a percentage reported as activity, at one concentration (the size of the read-out at that concentration, not a potency): 96%
Compound 4: middle estimate off by 1 percentage points, on the high side, within the range that was stated.
By their numbers in this assay, from the lowest: compounds 4, 1, 2 and 3 (each within the scatter of the next).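

On the carbonyl carbon, 3,4-difluorophenyl gives a number 2 percentage points lower from compound 3 to compound 4 (within the scatter) and a number 2 percentage points lower from compound 2 to compound 4 (within the scatter) in this assay as the read-out. A third aryl at this place, now with fluorine, therefore cannot be told apart from 4-methoxyphenyl or 3,4-dichlorophenyl at the one concentration tested. No data on a cause accompany these values.

Open, on these data alone, is whether any group at this place separates beyond the scatter, such as an aryl carrying an amine or a carboxylic acid. Potency also stays open, as a single-concentration read-out does not give it.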